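The source may hold more compounds than are shown below. What is called first, only, known or untested is meant among the compounds shown, and "the series" means these compounds.

Measured so far:
compound 1 `COc1ccc(NC(=O)C(=O)c2cn(CC(C)C)c3ccccc23)cn1`: 317 nM
compound 2 `COCCn1cc(C(=O)C(=O)Nc2ccc(OC)nc2)c2cccnc21`: 27 nM
compound 3 `COCCn1cc(C(=O)C(=O)Nc2ccncc2)c2ccccc21`: > 10000 nM, a limit of the assay

In a functional assay on FaDu cells (Homo sapiens) for cytotoxicity, read by MTT assay, with a stated time of 72 h (a lower number here means that less compound is tolerated, a higher number that more compound is tolerated), compound 1 stands at the higher of the two numbers, and compound 2 sits well beyond the scatter at a markedly lower one. For compound 3 the assay reports only a limit, (the limit of > 10000 nM in this assay, at which 1 of the 3 values shown sits), and no number. Compound 4 `COc1ccc(NC(=O)C(=O)c2cn(CC3CCCO3)c3ccccc23)cn1` differs from compound 1 in a single place: oxolan-2-yl in place of isopropyl on a saturated chain carbon bound to an aromatic nitrogen. Among the measured compounds shown here, no pair of measured compounds differing in one place exists here, so this change has no measured counterpart. The step is expected to be small, a 1.1-fold lower number from compound 1 to compound 4 (0.02 log units; within the scatter), with no shift beyond the scatter. Compound 4 is estimated at 300 nM, between 100 nM and 1500 nM.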

Compound 4, concentration lethal to 50% of the cells: 31 nM
For compound 4 the middle estimate is 9.7-fold (0.99 log units) above the measured one, outside the stated range (below it).
By their numbers in this assay, from the lowest: compounds 2 and 4 (each within the scatter of the next); then compound 1. At a limit, above all of these: compound 3.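

In this assay, the group on the saturated chain carbon bound to an aromatic nitrogen proves to matter: oxolan-2-yl in place of isopropyl gives a 10-fold lower number from compound 1 to compound 4 (1.01 log units; beyond the scatter) with the rest of the core unchanged. Among the compounds shown here, this is the only single-place step measured so far, and it shows that this one change can move the number well beyond the scatter. The data shown give no cause for the step.

Going by these compounds, whether the step follows the ring or its oxygen stays open, and a cyclopentyl group at this place would separate the two. On these data alone, how an amine or a longer chain would read in this assay also remains open.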